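Replacing a furan ring in a weak deacetylase inhibitor

This account rests on a few compounds, and the source may have more. Where it says the series, first, only, none or still open, it means among the compounds named here.

Measured compounds:
compound 1, `Cc1ccc(C2CC(c3ccccc3)=NN2C(=O)COc2ccc(/C=C3/SC(=O)NC3=O)cc2)cc1`, 31000 nM
compound 2, `O=C1NC(=O)/C(=C\c2ccc(OCC(=O)N3N=C(c4ccc(F)cc4F)CC3c3ccco3)cc2)S1`, > 50000 nM

Compound 1 `Cc1ccc(C2CC(c3ccccc3)=NN2C(=O)COc2ccc(/C=C3/SC(=O)NC3=O)cc2)cc1` gives 31000 nM in an assay on cells for inhibition of histone deacetylase 8 (Homo sapiens), read by fluorescence, with a stated time of 30 min (a lower number here means a stronger inhibitor, a higher number a weaker inhibitor), a weak result. Compound 2 `O=C1NC(=O)/C(=C\c2ccc(OCC(=O)N3N=C(c4ccc(F)cc4F)CC3c3ccco3)cc2)S1` gives only > 50000 nM in this assay, which is a limit of the assay and not a measured number. Of the two values shown, compound 2 is the one that sits at the limit of > 50000 nM in this assay, at which 1 of the 2 values shown sits. Going by the values given here, compound 1 and compound 2 differ in more than one place, so no single step between them is given; their values show only that compound 1 yielded a number and compound 2 did not.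

Compound 3 `Cc1ccc(C2CC(c3ccc(F)cc3F)=NN2C(=O)COc2ccc(/C=C3/SC(=O)NC3=O)cc2)cc1` differs from compound 2 by 4-methylphenyl in place of furan-2-yl on a saturated ring carbon, while the 2,4-difluorophenyl group of compound 2 is kept. Among the compounds with values here, no measured step covers this change. Compound 1 carries the same 4-methylphenyl group and gives a weak number, so the step from compound 2 to compound 3 is expected to be small, an at least 1.1-fold lower number from compound 2 to compound 3 (0.04 log units; that floor lies within the scatter), and possibly none beyond the scatter. Compound 3 is therefore estimated at 45000 nM, with a range from 15000 nM to 120000 nM.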

Compound 3, half-maximal inhibitory concentration: > 50000 nM
Compound 3 gave a limit, no number; the forecaster's own chance of this, stated with the estimate: 45%; at least 1.1-fold (0.04 log units) between middle value and limit.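

In this assay compound 3 gives > 50000 nM, which is a limit of the assay and not a number, so 4-methylphenyl in place of furan-2-yl on the saturated ring carbon did not yield a number with the 2,4-difluorophenyl group kept. Going by these compounds alone, the one step that can be read concerns the other change: 2,4-difluorophenyl in place of phenyl on a carbon with a double bond to nitrogen gives an at least 1.6-fold higher number from compound 1 to compound 3 (0.20 log units; that floor lies within the scatter), which leaves compound 1 as the only one of the three with a number. The step for the furan-2-yl change cannot be read, because both of its compounds stand at the limit: the limit of > 50000 nM in this assay, at which 2 of the 3 values shown sit.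

Going by these compounds, what the saturated ring carbon tolerates therefore stays open, and so does whether a group such as an amine or a carboxylic acid there would give a number in this assay. Also open, on these data alone, is whether furan-2-yl paired with an unsubstituted phenyl on the carbon with a double bond to nitrogen would give a number, which would allow the two groups on the saturated ring carbon to be compared directly.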